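Notes on the step from compound 3 to compound 4

The source may report more compounds than this note shows. Statements on the series, on what has been measured and on what is new or still open speak of the compounds shown alone.

Values in an ADME assay on cells (Homo sapiens) for cytotoxicity, read by resazurin assay, with a stated time of 5 days; on this read-out lower numbers stand for higher toxicity in this test and higher numbers for lower toxicity in this test:
- compound 1 `COc1ccc(-c2nc(C(F)(F)S(=O)(=O)c3cccc(Cl)c3)nc3ccsc23)cn1`: > 50000 nM (a limit, not a number)
- compound 2 `COc1ccc(-c2nc(C(C)(C)S(=O)(=O)c3cccc(Cl)c3)nc3ccsc23)cn1`: > 50000 nM (a limit, not a number)
- compound 3 `COc1ccc(Nc2nc(CS(=O)(=O)c3cccc(Cl)c3)nc3ccsc23)cc1`: 60000 nM

Within the data shown here, compound 3, at 60000 nM, holds the only actual number. Compound 1 and compound 2 are known only through (the limit of > 50000 nM in this assay, at which 2 of the 3 values shown sit).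

Compound 4 `O=S(=O)(Cc1nc(-c2ccc(Cl)nc2)c2sccc2n1)c1cccc(Cl)c1` has not yet been measured. It carries 6-chloropyridin-3-yl in place of (4-methoxyphenyl)amino on an aromatic carbon of the six-membered aromatic ring with 2 nitrogen, part of a fused or bridged system of two rings (6-chloropyridin-3-yl in place of (4-methoxyphenyl)amino on an aromatic carbon).

Among the measured compounds shown here, no two measured compounds differ in one place only, so no measured step shows the size of this change. For the measured compounds named here, the expectation therefore rests on the values alone: compound 3 gives 60000 nM and no measured compound shows a lower number in this assay. The expected step is small, with no shift beyond the usual scatter in either direction: a 1.2-fold lower number from compound 3 to compound 4 (0.08 log units; within the scatter). A report of compound 4 as a limit would not be a surprise. For compound 4 the estimated value is 50000 nM, with an expected range from 20000 nM to 100000 nM.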

Compound 4, half-maximal cytotoxic concentration: 70000 nM
Compound 4: middle estimate off by 1.4-fold (0.15 log units), on the low side, and the stated range covers the measured number.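

In this assay the series now has its first step in one place, a 1.2-fold higher number from compound 3 to compound 4 (0.07 log units; within the scatter), so the size of this change no longer has to be inferred from the values alone. On an aromatic carbon of the six-membered aromatic ring with 2 nitrogen, a group with a hydrogen-bond donor and a methoxy-bearing carbon-only aromatic ring gives way to 6-chloropyridin-3-yl, which has no hydrogen-bond donor, yet the two values stay within the scatter of each other. For this one pair, then, the read-out does not separate (4-methoxyphenyl)amino from 6-chloropyridin-3-yl, and both compounds sit at the mild end of this test, though a single pair sets no rule for the position.

Compound 1 and compound 2 offer only a limit and no number to compare with: the limit of > 50000 nM in this assay, at which 2 of the 4 values shown sit. Going by these compounds, it remains open whether a carboxylic acid or a piperazine at this position would give a number clearly apart from those of compound 3 and compound 4.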